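Swapping Chloro for Propyl: What Compound 4 Might Give

The source may report more compounds than this note shows. Statements on the series, on what has been measured and on what is new or still open speak of the compounds shown alone.

Of the compounds shown here, three sharing one core have been tested in a functional assay on the whole organism for inhibition, with Rattus norvegicus as the target, at a dose of 10 mg/kg by the oral route; a lower number here means a weaker effect, a higher number a stronger effect of the compound at the dose given. Compound 1 `O=C(Nc1nn[nH]n1)c1cccc(CCc2ccccc2)n1` gives 45%. Compound 2 `CCCCc1cccc(C(=O)Nc2nn[nH]n2)n1` gives 18%. Compound 3 `O=C(Nc1nn[nH]n1)c1cccc(Cl)n1` gives 13%, the lowest of the three numbers, though its gap to compound 2 is within the scatter; only its gap to compound 1 lies beyond it. Compound 4 `CCCc1cccc(C(=O)Nc2nn[nH]n2)n1` has not been measured. It differs from compound 3 in one place: propyl in place of chloro on an aromatic carbon. For the measured compounds named here, the step that bears most on this change is the one where the reverse swap, chloro in place of butyl, brought a number 5 percentage points lower from compound 2 to compound 3 (within the scatter). The larger step, a number 27 percentage points lower from compound 1 to compound 2 (beyond the scatter), concerns a change elsewhere on the molecule and says little here. Since chloro and butyl gave numbers within the scatter of each other, propyl is expected to behave much like butyl, so the step of a number 4 percentage points higher from compound 3 to compound 4 (within the scatter) is expected to stay within the scatter. Compound 4 is therefore estimated at 17%, in a range from 4% to 32%.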

Compound 4, a percentage reported as inhibition, in the whole organism at one dose (the size of the read-out at that dose, not a potency): 38%
Compound 4: the middle estimate sits 21 percentage points below what was measured, outside the stated range (above it).
By their numbers in this assay, from the lowest: compounds 3 and 2 (each within the scatter of the next); then compounds 4 and 1 (each within the scatter of the next).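

In this assay, this position next to the ring nitrogen proves sensitive to what sits on it, since with propyl in place of chloro there is a number 25 percentage points higher from compound 3 to compound 4 (beyond the scatter). Chain length matters too: with butyl cut back to propyl there is a number 20 percentage points higher from compound 2 to compound 4 (beyond the scatter), so the closeness of chloro and butyl had hidden a real dependence on the group at this place. The result also shows that the phenyl at the end of the chain in compound 1 is not needed to reach this level, as a number 7 percentage points lower from compound 1 to compound 4 (within the scatter) stays within the scatter.

Nothing available explains why propyl stands apart from butyl. On these data alone, how an ethyl chain, a branched isopropyl group or an amine at this position would compare remains open.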